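A Nitro Group on the Phenyl of Compound 3

This account rests on a few compounds, and the source may have more. Where it says the series, first, only, none or still open, it means among the compounds named here.

Measured in a functional assay on WM 266-4 cells (Homo sapiens) for inhibition, with a stated time of 72 h; on this read-out higher numbers stand for weaker inhibition and lower numbers for stronger inhibition:
- compound 1 `CNC(=O)C1=C[C@@H]2[C@@H](C(C)C)CC[C@@](O)(CO)[C@H]2C(=O)OC1`: > 32000 nM (a limit)
- compound 2 `COC(=O)C1=C[C@@H]2[C@@H](C(C)C)CC[C@@]3(CO3)[C@H]2C(=O)OC1`: 4100 nM
- compound 3 `CC(C)[C@H]1CC[C@@]2(CO2)[C@H]2C(=O)OCC(C(=O)OCc3ccc(-c4ccccc4)o3)=C[C@H]12`: 960 nM

The reading for compound 1 is a limit and not a number. Among the two true numbers in this assay, compound 3 stands lowest at 960 nM, and the gap to compound 2 at 4100 nM lies beyond the scatter. Among the measured compounds shown here, compound 3 therefore gives the strongest inhibition of the series so far.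

The next compound, compound 4 `CC(C)[C@H]1CC[C@@]2(CO2)[C@H]2C(=O)OCC(C(=O)OCc3ccc(-c4ccc([N+](=O)[O-])cc4)o3)=C[C@H]12`, has not yet been measured. It differs from compound 3 by nitro in place of hydrogen on an aromatic carbon, para to a large group, which turns phenyl into 4-nitrophenyl: nitro in place of hydrogen on an aromatic carbon. For the measured compounds named here, no pair of measured compounds differs in one place alone, so the data give no direct guide to this change.

The expected outcome in this assay is a shift no larger than the scatter, leaning slightly toward stronger inhibition: a 1.2-fold lower number from compound 3 to compound 4 (0.08 log units; within the scatter). For compound 4 the estimated value is 800 nM, with an expected range from 250 nM to 2600 nM.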

Compound 4, half-maximal inhibitory concentration: 3600 nM
Compound 4: middle estimate off by 4.5-fold (0.65 log units), on the low side, outside the stated range (above it).
By their numbers in this assay, from the lowest: compound 3; then compounds 4 and 2 (each within the scatter of the next). At a limit, above all of these: compound 1.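

In this assay nitro in place of hydrogen on an aromatic carbon, para to a large group, gives a 3.8-fold higher number from compound 3 to compound 4 (0.57 log units; beyond the scatter) and so weakens inhibition modestly. Among the compounds shown here, this is the first comparison that changes one place alone, and it shows that the phenyl of compound 3 does not tolerate every substituent at this position without loss. Nothing measured here accounts for this loss of inhibition.

As far as these compounds go, whether the loss belongs to nitro itself or would follow any group at this position stays open, since an amine, a fluorine atom or a methoxy group there would separate the two readings. Also open, from the compounds shown here alone, is how nitro would fare elsewhere on the same six-membered ring, and whether the unsubstituted phenyl is the best group on the furan-bearing ester chain.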